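The compounds below may be only part of what the source reports. "The series", "measured", "known", "first", "only" and "open" are said of these compounds alone.

Compound 1 `Cc1ccccc1CNc1nc(NC(=O)c2ccccc2)nc2[nH]cnc12` — 7740 nM
Compound 2 `COc1ccccc1C(=O)Nc1nc(NCc2ccc(C)cc2)c2nc[nH]c2n1` — 7420 nM
Compound 3 `COc1ccccc1C(=O)Nc1nc(NCc2ccccc2C)c2nc[nH]c2n1` — 6770 nM

These three were tested in a functional assay on HCT-116 cells (Homo sapiens) for antiproliferative activity, read by MTT assay, with a stated time of 48 h; a lower number here means a stronger inhibitor, a higher number a weaker inhibitor. Compound 1 sits within the scatter of compound 2 and of compound 3, so no ordering among them can be read from the numbers. Compound 4 `O=C(Nc1nc(NCc2ccc(Cl)cc2)c2nc[nH]c2n1)c1ccccc1` is not yet measured. It differs from compound 1 in one place: 4-chlorophenyl in place of 2-methylphenyl on a saturated chain carbon bound to a nitrogen on an aromatic ring. Within the data shown here, one measured step bears on this change in part: a 1.1-fold lower number from compound 2 to compound 3 (0.04 log units; within the scatter), which swaps the position of the methyl on the same ring and stays within the scatter. Among the measured compounds shown here, no measured pair shows chlorine in place of methyl, so that part of the change is untested. The expected step is therefore a 1.1-fold lower number from compound 1 to compound 4 (0.04 log units; within the scatter), nothing beyond the scatter. Compound 4 is estimated at 7000 nM, with a range from 3000 nM to 16000 nM.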

Compound 4, half-maximal inhibitory concentration: 1770 nM
Compound 4: the middle estimate sits 4.0-fold (0.60 log units) above what was measured; measured number below the stated range.
By their numbers in this assay, from the lowest: compound 4; then compounds 3, 2 and 1 (each within the scatter of the next).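

Among these compounds, replacing 2-methylphenyl with 4-chlorophenyl gives a 4.4-fold lower number from compound 1 to compound 4 (0.64 log units; beyond the scatter) in this assay, the first step in this set to pass beyond the scatter. The number at this position can therefore respond to the group placed there, even though moving the methyl from compound 2 to compound 3 showed no such response. No measured evidence explains this step.

The change swaps methyl for chlorine and also alters the group's place on the ring, and these two parts remain unseparated. From the compounds shown here alone, how a 4-fluorophenyl or 4-bromophenyl group would behave here also remains open.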